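Cyano for bromo across a thioether and a sulfoxide pair

The source may hold more compounds than are shown below. What is called first, only, known or untested is meant among the compounds shown, and "the series" means these compounds.

Compound 1 `N#Cc1c(N)cccc1Sc1cccc(Br)c1` and compound 2 `N#Cc1cccc(Sc2cccc(N)c2C#N)c1` share one core, while compound 3 `N#Cc1c(N)cccc1[S+]([O-])c1ccc(Br)cc1` and compound 4 `N#Cc1ccc([S+]([O-])c2cccc(N)c2C#N)cc1` share another; the difference between the two cores is not broken down here. In a functional assay on MT4 cells (Homo sapiens) for cytotoxicity (on this read-out lower numbers stand for stronger inhibition and higher numbers for weaker inhibition), compound 1 gives 53000 nM. In this assay compound 2 gives 80000 nM. The change between them is cyano in place of bromo on an aromatic carbon, and it made a 1.5-fold higher number from compound 1 to compound 2 (0.18 log units; within the scatter). For compound 3 this assay reports only a limit, > 200000 nM, which is the limit of > 200000 nM in this assay, at which 1 of the 3 values shown sits. From compound 3 to compound 4 the same kind of change is made, (cyano in place of bromo on an aromatic carbon), the place differing only in that it is para to a large group rather than meta to a large group. Resting on a 1.5-fold higher number from compound 1 to compound 2 (0.18 log units; within the scatter), the step is expected to be a number no higher from compound 3 to compound 4 (the limit leaves the size open). Compound 4 is therefore expected to give 200000 nM, most likely again as a limit.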

Compound 4, half-maximal inhibitory concentration: > 200000 nM
Compound 4: only a limit was reported; the forecaster's own chance of this, stated with the estimate: 80%; the middle value lies on the limit itself.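

Compound 3 and compound 4 are both reported only as limits in this assay, so no step can be read between them: the limit of > 200000 nM in this assay, at which 2 of the 4 values shown sit.

The compounds shown leave open whether cyano in place of bromo shifts the number on the core of compound 3.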